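Distal aryl swap in the aminoquinoline series: acid dissociation

The source may report more compounds than this note shows. Statements on the series, on what has been measured and on what is new or still open speak of the compounds shown alone.

Compound 3 `COc1cccc(CNCCCNc2ccnc3cc(Cc4cccc(C(F)(F)F)c4)ccc23)c1O` gives 9.47 in a physicochemical assay for acid dissociation. Compound 2 `COc1cccc(CNCCCNc2ccnc3cc(Cc4ccc(F)cc4)ccc23)c1O` gives 9.47, and the step of no change at the digits printed from compound 2 to compound 3 (within the scatter) shows the two level with each other. Compound 1 `COc1cccc(Oc2ccc3c(NCCCNCc4cccc(OC)c4O)ccnc3c2)c1` gives 9.28; the step of a number 0.19 log units higher from compound 1 to compound 3 (within the scatter) and the step of a number 0.19 log units higher from compound 1 to compound 2 (within the scatter) both stay within the scatter, so the three measured numbers cannot be told apart.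

Compound 4 `COc1cccc(CNCCCNc2ccnc3cc(Cc4ccc(F)cc4Cl)ccc23)c1O` differs from compound 3 as follows: 2-chloro-4-fluorophenyl in place of 3-(trifluoromethyl)phenyl on a saturated chain carbon bound to an aromatic carbon. The step that bears most directly on this change is no change at the digits printed from compound 2 to compound 3 (within the scatter), where the aryl group on the benzyl carbon was exchanged with no movement in the read-out; the larger exchange a number 0.19 log units higher from compound 1 to compound 3 (within the scatter) also stayed within the scatter. The acid dissociation measured here therefore appears insensitive to what sits on the saturated chain carbon bound to the aromatic carbon, at least within the three compounds measured. The expected step is no change at the digits printed from compound 3 to compound 4 (within the scatter), none beyond the scatter. Compound 4 is estimated at 9.47, with a range from 9.2 to 9.75.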

Compound 4, acid dissociation constant: 9.47
Beside the measured number, compound 4's estimate shows no gap at the digits printed, within the range that was stated.
By their numbers in this assay, from the lowest: compounds 1, 2, 3 and 4 (each within the scatter of the next).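

In this assay, 2-chloro-4-fluorophenyl in place of 3-(trifluoromethyl)phenyl on a saturated chain carbon bound to an aromatic carbon gives no change at the digits printed from compound 3 to compound 4 (within the scatter), and this result adds a single chloro in place of hydrogen on an aromatic carbon, with no change at the digits printed from compound 2 to compound 4 (within the scatter). Set against 3-methoxyphenoxy, the 2-chloro-4-fluorobenzyl group gives a number 0.19 log units higher from compound 1 to compound 4 (within the scatter), so a third benzyl group joins the two earlier ones without a step beyond the scatter. Nothing shown accounts for this flat read-out.

Still open, on these data alone, is whether an amine or a carboxylic acid in place of the chloro would give a step beyond the scatter in this assay. A longer chain in place of the benzyl carbon also remains an open case at this position.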